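A Chloro Step Read Across Two Related Cores

This account rests on a few compounds, and the source may have more. Where it says the series, first, only, none or still open, it means among the compounds named here.

Measured compounds in a functional assay on cells (Cancer cell lines, Homo sapiens) for cytotoxicity, read by sulforhodamine B assay, with a stated time of 48 h; on this read-out higher numbers stand for weaker inhibition of growth and lower numbers for stronger inhibition of growth:
compound 1, `Oc1ccc(O)c(-c2cc(-c3ccccc3)nn2-c2ccccc2)c1`, 28500 nM
compound 2, `Oc1ccc(O)c(-c2cc(-c3ccc(Cl)cc3)nn2-c2ccccc2)c1`, 5750 nM
compound 3, `CC(=O)NS(=O)(=O)c1ccc(-n2nc(-c3ccccc3)cc2-c2cc(O)ccc2O)cc1`, 78600 nM

Compound 1 and compound 2 differ by one change, (chloro in place of hydrogen on an aromatic carbon), and that change gave a 5.0-fold lower number from compound 1 to compound 2 (0.70 log units; beyond the scatter). Compound 3 differs from compound 1 in its core by acetylsulfamoyl in place of hydrogen on an aromatic carbon, which gave a 2.8-fold higher number from compound 1 to compound 3 (0.44 log units; beyond the scatter), so compound 3 stands highest of the three in this assay. Compound 4, `CC(=O)NS(=O)(=O)c1ccc(-n2nc(-c3ccc(Cl)cc3)cc2-c2cc(O)ccc2O)cc1`, has not been measured. It differs from compound 3 by chloro in place of hydrogen on an aromatic carbon, which is the same change that turns compound 1 into compound 2, made on the core of compound 3 instead.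

Because the step of a 5.0-fold lower number from compound 1 to compound 2 (0.70 log units; beyond the scatter) was measured on a core that differs from that of compound 3 only by the acetylsulfamoyl group, the same change is expected to carry over, and compound 4 is expected to show a step of a 5.0-fold lower number from compound 3 to compound 4 (0.70 log units; beyond the scatter) from compound 3. On that basis compound 4 is estimated at 15700 nM in this assay, with an expected range from 7000 nM to 40000 nM, the width allowing for the chance that the chloro step does not repeat fully on the second core.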

Compound 4, concentration for 50% growth inhibition: 37600 nM
Compound 4: the middle estimate sits 2.4-fold (0.38 log units) below what was measured, and the stated range covers the measured number.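

In this assay the chloro change went the same way on the core of compound 3 as on the core of compound 1, with a 2.1-fold lower number from compound 3 to compound 4 (0.32 log units; beyond the scatter), and the two steps do not differ beyond what repeated measurement allows: the same change on two cores in this assay, a 5.0-fold lower number (0.70 log units; beyond the scatter) from compound 1 to compound 2 and a 2.1-fold lower number (0.32 log units; beyond the scatter) from compound 3 to compound 4, 2.4-fold (0.37 log units) apart, within the scatter of two such steps. Read the other way, acetylsulfamoyl in place of hydrogen raised the number on both cores, with a 6.5-fold higher number from compound 2 to compound 4 (0.82 log units; beyond the scatter), and this pair of steps agrees in the same way: the same change on two cores in this assay, a 2.8-fold higher number (0.44 log units; beyond the scatter) from compound 1 to compound 3 and a 6.5-fold higher number (0.82 log units; beyond the scatter) from compound 2 to compound 4, 2.4-fold (0.37 log units) apart, within the scatter of two such steps. The change therefore carried over in direction and, within the scatter, in size, but this rests on one pair of cores in one assay and does not show that it would carry to any other core.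

The compounds shown leave open whether a bromo, a methoxy or an amine in place of the chloro would behave alike on both cores. They also leave open whether a carboxylic acid in place of the acetylsulfamoyl group would change the size of the chloro step.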